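Reversed enone with dimethylphenyl on the shared core

The compounds below may be only part of what the source reports. "The series", "measured", "known", "first", "only" and "open" are said of these compounds alone.

Compound 2 `COc1cc(-c2cc(C(=O)/C=C/c3ccc(Cl)cc3)nc3cc(-c4ccccc4)nn23)cc(OC)c1OC` gives 21600 nM in a functional assay on MDA-MB-231 cells (Homo sapiens) for antiproliferative activity, read by MTT assay, with a stated time of 24 h (a lower number here means a stronger inhibitor, a higher number a weaker inhibitor), the second highest of the three numbers shown. Compound 3 `COc1ccc(-c2cc(C(=O)/C=C/c3ccc(Cl)cc3)nc3cc(-c4ccccc4)nn23)cc1OC` gives 23700 nM in this assay, and a 1.1-fold higher number from compound 2 to compound 3 (0.04 log units; within the scatter). Compound 1 `COc1ccc(-c2cc(/C=C/C(=O)c3cc(OC)c(OC)c(OC)c3)nc3cc(-c4ccccc4)nn23)cc1OC` gives 4700 nM in this assay; compound 1 differs from compound 2 in two places, so only its value is available for comparison. Compound 4 `COc1cc(-c2cc(/C=C/C(=O)c3ccc(C)c(C)c3)nc3cc(-c4ccccc4)nn23)cc(OC)c1OC` is not yet measured. It carries 2-((3,4-dimethylphenyl)carbonyl)ethenyl in place of (2-(4-chlorophenyl)ethenyl)carbonyl on an aromatic carbon. Among the measured compounds shown here, no measured step covers this change; the step from compound 2 to compound 3 touches the other aryl group and is within the scatter. Compound 4 is expected near 10000 nM in this assay, within 3000 nM to 35000 nM, which means an expected 2.2-fold lower number from compound 2 to compound 4 (0.33 log units; beyond the scatter).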

Compound 4, half-maximal inhibitory concentration: 13500 nM
Compound 4: middle estimate off by 1.4-fold (0.13 log units), on the low side, and the stated range covers the measured number.
By their numbers in this assay, from the lowest: compound 1; then compounds 4, 2 and 3 (each within the scatter of the next).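

In this assay, placing 2-((3,4-dimethylphenyl)carbonyl)ethenyl in place of (2-(4-chlorophenyl)ethenyl)carbonyl at this position gives a 1.6-fold lower number from compound 2 to compound 4 (0.20 log units; within the scatter), so this exchange stays within the scatter even though it reverses the enone and changes the aryl group at once. The two parts of the exchange cannot be separated with these compounds. Nothing measured here explains this result.

Still open, from the compounds shown here alone, is how the same enone direction behaves with a 4-chlorophenyl ketone. Also open, going by these compounds, is whether an amine or a carboxylic acid on that aryl ring would move the number.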